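The compounds below may be only part of what the source reports. "The series", "measured", "known", "first", "only" and "open" are said of these compounds alone.

Compound 1 `COc1ncnc2c1c(-c1cc3ccccc3o1)cn2[C@@H]1O[C@H](CO)[C@@H](O)[C@H]1O`: 13100 nM
Compound 2 `Cc1nc(N)c2c(-c3ccoc3)cn([C@@H]3O[C@H](CO)[C@@H](O)[C@H]3O)c2n1`: > 20000 nM
Compound 3 `Nc1nc2c(c(-c3cccs3)cn2[C@@H]2O[C@H](CO)[C@@H](O)[C@H]2O)c(=O)[nH]1`: 16800 nM

These three compounds were measured in a functional assay on K562 cells (Homo sapiens), read by MTT assay, with a stated time of 72 h; a higher number here means a weaker inhibitor, a lower number a stronger inhibitor. Compound 1 and compound 3 give real numbers, and these two values lie close together.

Compound 2 gives no number, only a limit of the assay: > 20000 nM. Its place in the series is therefore known only roughly: the limit of > 20000 nM in this assay, at which 1 of the 3 values shown sits.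

Compound 4 `Cc1nc(N)c2c(I)cn([C@@H]3O[C@H](CO)[C@@H](O)[C@H]3O)c2n1` keeps the rest of compound 2 and changes one group: iodo in place of furan-3-yl on an aromatic carbon. Among the compounds with values here, no measured pair in this small set shows what such a swap does, so the expectation is loose. The three measured compounds all sit at the weak end of this assay, so no large gain is assumed, and a clear shift in either direction is not expected. The estimated change is an at least 1.1-fold lower number from compound 2 to compound 4 (0.04 log units; that floor lies within the scatter). Another limit would be no surprise. For compound 4 the expected value is 18000 nM, with an estimated range from 4000 nM to 40000 nM.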

Compound 4, half-maximal inhibitory concentration: 1110 nM
The estimate for compound 4 lay 16-fold (1.21 log units) above the measured number; the whole stated range lies above it.
By their numbers in this assay, from the lowest: compound 4; then compounds 1 and 3 (each within the scatter of the next). At a limit, above all of these: compound 2.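

Putting iodo in place of furan-3-yl gives an at least 18-fold lower number from compound 2 to compound 4 (1.25 log units; beyond the scatter) in this assay. This shows that the group on this aromatic carbon, two ring bonds from the ring nitrogen, can strongly change the read-out on this core, and that a single iodine atom with no ring is enough to move a compound away from the weak end of the assay. The true size of the step is unknown and may be larger, because compound 2 gives only a limit: the limit of > 20000 nM in this assay, at which 1 of the 4 values shown sits.

The compounds shown cannot tell whether the change comes from iodine itself or simply from the loss of the furan ring. A chloro group, a bromo group, a methyl group or a phenyl ring at the same carbon would help separate these two readings.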